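Chloro-substituted phenylureas: scatter and one unmeasured analogue

The source may report more compounds than this note shows. Statements on the series, on what has been measured and on what is new or still open speak of the compounds shown alone.

Compound 1 `C[C@@H](NC(=O)Nc1ccccc1Cl)c1ccccc1` is measured in an ADME assay on the whole organism with Oryza sativa as the target, tested at 10 uM (a lower number here means a stronger effect, a higher number a weaker effect of the compound at the concentration tested), where compound 1 gives 93%. Compound 2 `C[C@H](NC(=O)Nc1ccccc1Cl)c1ccccc1` shares every atom and bond with compound 1; the cores differ only in that (the two compounds have the same atoms and bonds and differ only in configuration as drawn: 1 of 1 stereo elements differ; a stereocentre at a saturated chain carbon is drawn S in compound 2 and R in compound 1). In this assay compound 2 gives 106%, a step of a number 13 percentage points higher from compound 1 to compound 2 (beyond the scatter), which rests on (the fact that compounds 1 and 2 differ only in the configuration as drawn). Compound 3 `C[C@H](NC(=O)Nc1cccc(Cl)c1Cl)c1ccccc1` carries the change (chloro in place of hydrogen on an aromatic carbon), and in this assay compound 3 gives 101%, a step of a number 5 percentage points lower from compound 2 to compound 3 (within the scatter).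

Compound 4 `C[C@@H](NC(=O)Nc1c(Cl)cccc1Cl)c1ccccc1` is not yet measured. From compound 1 it carries the same kind of change, (chloro in place of hydrogen on an aromatic carbon), though the place differs: here the entering chloro is ortho to a large group and meta to a chloro group, whereas in compound 3 it is ortho to a chloro group and meta to a large group. The step for compound 4 in this assay is expected to be a number 3 percentage points lower from compound 1 to compound 4 (within the scatter), resting on the step of a number 5 percentage points lower from compound 2 to compound 3 (within the scatter) lying within the scatter. Compound 4 is therefore estimated at 90%, between 76% and 104%.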

Compound 4, a percentage reported as activity, at one concentration (the size of the read-out at that concentration, not a potency): 100%
Estimate against measurement, compound 4: 10 percentage points below, and the stated range covers the measured number.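

In this assay, chloro in place of hydrogen on an aromatic carbon, ortho to a large group and meta to a chloro group, gives a step of a number 7 percentage points higher from compound 1 to compound 4 (within the scatter) and so leaves the read-out indistinguishable from that of the parent. Neither step shows an effect of the added chloro, and this pair shows that the change carries between these two cores without a detectable difference: the same change on two cores in this assay, a number 5 percentage points lower (within the scatter) from compound 2 to compound 3 and a number 7 percentage points higher (within the scatter) from compound 1 to compound 4, 12 percentage points apart, within the scatter of two such steps

This does not show that the change would behave alike on other cores, or at a read-out where a step could rise beyond the scatter, since the two steps also differ in the place of the chloro.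

The compounds shown leave open whether fluoro, methoxy or an amine on the aromatic ring would move the read-out beyond the scatter. They also leave open what a longer chain in place of the methyl on the saturated chain carbon would do.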